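The source may hold more compounds than are shown below. What is called first, only, known or untested is meant among the compounds shown, and "the series" means these compounds.

Two compounds share the same core and differ only in the group at the far end of the chain. Compound 1 `O=C(CCCCCCc1ccc(Cl)cc1)c1ncc(-c2ccccn2)o1` gives 2.7 nM in an assay for inhibition of Fatty-acid amide hydrolase 1 (Rattus norvegicus); on this read-out lower numbers stand for stronger inhibition and higher numbers for weaker inhibition. Compound 2 `COc1ccc(CCCCCCC(=O)c2ncc(-c3ccccn3)o2)cc1` gives 6.2 nM in this assay, the higher of the two numbers; the step of a 2.3-fold higher number from compound 1 to compound 2 (0.36 log units; beyond the scatter) shows that swapping the group at this position moves the read-out by a modest amount. Compound 3 `CS(=O)(=O)c1ccc(CCCCCCC(=O)c2ncc(-c3ccccn3)o2)cc1` carries the change (methylsulfonyl in place of methoxy on an aromatic carbon). Among the measured compounds shown here, no measured step involves methylsulfonyl, so the only guidance is the step from compound 1 to compound 2, which was modest in size. A change at the same position is therefore expected to shift the number by a similar or somewhat larger amount, most likely upward, since compound 2 already stands higher than compound 1. Compound 3 is estimated at 12 nM in this assay, within 4 nM to 40 nM, meaning an expected step of a 1.9-fold higher number from compound 2 to compound 3 (0.29 log units; within the scatter).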

Compound 3, inhibition constant: 19 nM
Compound 3: middle estimate off by 1.6-fold (0.20 log units), on the low side, within the range that was stated.
By their numbers in this assay, from the lowest: compound 1; then compound 2; then compound 3.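

Replacing methoxy with methylsulfonyl gives a 3.1-fold higher number from compound 2 to compound 3 (0.49 log units; beyond the scatter) in this assay, so the read-out at this position keeps moving in the same direction that it took when methoxy replaced chloro. Replacing chloro with methylsulfonyl gives a 7.0-fold higher number from compound 1 to compound 3 (0.85 log units; beyond the scatter), which places the three groups in a clear order, with every step among them beyond the scatter, although even this widest step still counts as modest. No measurement shown here explains this order.

As far as these compounds go, it remains open whether an amine or a carboxylic acid, para to a large group on the same ring, would raise the number further or bring it back down. A fluoro group or a plain hydrogen at that place would show whether chloro is near the low end of the range.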